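Chain length and activity in one membrane potential series

A few compounds are considered here, and "the series" means these few. Any claim that something is new, unique, unknown or untested is made for them only; others in the source may bear on it.

Measured so far:
compound 1 `CCCCCCCCCCCCCCCCc1c(C)c(N(C)C)nc(C)c1O`, 91%
compound 2 `CCCCCCCCCCc1c(C)c(N(C)C)nc(C)c1O`, 89%
compound 3 `CCCCCCCCCCc1nc(N(C)C)c(C)c(C)c1O`, 90%

In a functional assay on cells (Lymphocyte, Homo sapiens) for inhibition, read by flow cytometry, using a membrane potential dye, with a stated time of 16 h, tested at 500 nM (on this read-out lower numbers stand for a weaker effect and higher numbers for a stronger effect at the one concentration tested), the three numbers sit close together. Compound 2 has the smallest of them, but compound 3 and compound 1 both fall within the usual scatter of it, so no order among the three can be read from these values.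

Compound 4 `CCCCCCCCCCCCCCCCCCCc1c(C)c(N(C)C)nc(C)c1O` differs from compound 2 by nonyl in place of hydrogen on a saturated chain carbon, ten or more bonds along the chain from an aromatic carbon. Among the measured compounds shown here, the only measured step of the same kind runs the other way: a number 2 percentage points lower from compound 1 to compound 2 (within the scatter). That removal of chain left the read-out unchanged beyond the scatter, so a longer chain is expected to do likewise. The expected step is no change at the digits printed from compound 2 to compound 4 (within the scatter). Compound 4 is therefore estimated at 89%, within 78% to 98%.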

Compound 4, a percentage reported as activity, at one concentration (the size of the read-out at that concentration, not a potency): 64%
For compound 4 the middle estimate is 25 percentage points above the measured one, and the stated range ends above it.
By their numbers in this assay, from the lowest: compound 4; then compounds 2, 3 and 1 (each within the scatter of the next).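

In this assay nonyl in place of hydrogen gives a number 25 percentage points lower from compound 2 to compound 4 (beyond the scatter) and propyl in place of hydrogen on the already long chain gives a number 27 percentage points lower from compound 1 to compound 4 (beyond the scatter) at this saturated chain carbon. Chain growth here is therefore not neutral throughout, although the hexyl difference between compound 1 and compound 2 stayed within the scatter. The length at which the read-out starts to fall lies somewhere past the chain of compound 1. No evidence at hand accounts for this fall. As far as these compounds go, whether a still longer chain lowers the read-out further, and whether an amine or a carboxylic acid at this place restores it, stays open.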